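The compounds below may be only part of what the source reports. "The series", "measured", "known", "first", "only" and "open" are said of these compounds alone.

Measured compounds in this series:

Compound 1 `O=c1oc(-c2ccccc2I)nc2ccccc12` — in an assay on isolated protein for inhibition of complement C1r subcomponent (Homo sapiens) (on this read-out higher numbers stand for weaker inhibition and lower numbers for stronger inhibition), compound 1 gives 16700 nM.
Compound 2 `O=c1oc(-c2ccc(I)cc2)nc2ccccc12` — in this assay compound 2 reaches only the limit > 62500 nM.
Compound 3 `COc1ccccc1-c1nc2ccccc2c(=O)o1` — in this assay compound 3 likewise reaches only the limit > 62500 nM.

Among the compounds with values here, compound 3 therefore stands at a limit and not at a number; compound 1 is the only compound with a measured number, and compound 2 also sits at a limit. Within the data shown here, the one step that reaches compound 3 is an at least 3.7-fold higher number from compound 1 to compound 3 (0.57 log units; beyond the scatter), which means iodo on the aromatic carbon gave a number while methoxy did not. This rests on (the limit of > 62500 nM in this assay, at which 2 of the 3 values shown sit), so the size of that weakening is only a lower bound.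

The next compound, compound 4 `O=c1oc(-c2ccccc2C(F)(F)F)nc2ccccc12`, differs from compound 3 by trifluoromethyl in place of methoxy on an aromatic carbon. Among the measured compounds shown here, no measured step covers trifluoromethyl, so the expectation leans on compound 3 alone, whose value in this assay is a limit. Compound 4 is expected to come out near 40000 nM, within 12000 nM to 130000 nM. That corresponds to an estimated at least 1.5-fold lower number from compound 3 to compound 4 (0.19 log units; that floor lies within the scatter), with a real chance that the assay again returns only a limit.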

Compound 4, half-maximal inhibitory concentration: 35400 nM
For compound 4 the middle estimate is 1.1-fold (0.05 log units) above the measured one, within the range that was stated.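

Trifluoromethyl is the second group, after iodo, to return a number rather than a limit when placed on this aromatic carbon, ortho to a large group, so a measurable reading in this assay is not unique to iodo. Against methoxy, the change is an at least 1.7-fold lower number from compound 3 to compound 4 (0.24 log units; that floor lies within the scatter); compound 3 stands at a limit, so this gives only a floor that does not clear the scatter, and no firm gain over methoxy can be claimed from it: the limit of > 62500 nM in this assay, at which 2 of the 4 values shown sit. Against iodo, the change is a 2.1-fold higher number from compound 1 to compound 4 (0.33 log units; beyond the scatter), which is beyond the scatter, so of the two groups with numbers at this position, trifluoromethyl gives the weaker inhibition.

The compounds shown leave open how an amine, a carboxylic acid, a chlorine or a longer chain such as ethoxy would read at this position, so two numbers do not yet make a trend across groups. On these data alone, how far compound 3 really lies from compound 4 also stays open, as does whether trifluoromethyl would keep a measurable reading elsewhere on the same ring.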